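This account rests on a few compounds, and the source may have more. Where it says the series, first, only, none or still open, it means among the compounds named here.

Measured compounds and values:

compound 1, `COCOc1ccc(C(=O)/C=C/c2ccc(OC)c(CC=C(C)C)c2)c(O)c1` — > 261000 nM (a limit, not a number)
compound 2, `COc1ccc(C(=O)/C=C/c2ccc(OC)c(CC=C(C)C)c2)c(O)c1` — > 283000 nM (a limit, not a number)
compound 3, `COCOc1ccc(C2CC(=O)c3ccc(OC)cc3O2)cc1CC=C(C)C` — 25100 nM

The read-out throughout is an assay on isolated protein for inhibition of Aromatase (Homo sapiens); on this read-out lower numbers stand for stronger inhibition and higher numbers for weaker inhibition. Compound 1 gives only a limit in this assay, > 261000 nM. Compound 2 likewise gives only a limit, > 283000 nM. Between them stands the change (hydrogen in place of methoxy on a saturated chain carbon bound to an oxygen on an aromatic ring), and the step that the two limits leave unreadable from compound 1 to compound 2 cannot be read because both values sit at a limit, the limit of > 261000 nM in this assay, at which 1 of the 3 values shown sits, and (the limit of > 283000 nM in this assay, at which 1 of the 3 values shown sits). Within the data shown here, compound 3 is the one compound of the three that returns a number in this assay, 25100 nM. Compound 3 has the same atoms as compound 1 joined differently; the difference between the two cores is not broken down here.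

Compound 4, `COc1ccc2c(c1)OC(c1ccc(OC)c(CC=C(C)C)c1)CC2=O`, is not yet measured. It differs from compound 3 by hydrogen in place of methoxy on a saturated chain carbon bound to an oxygen on an aromatic ring, which is the same change that leads from compound 1 to compound 2, at a place described in the same words. Among the measured compounds shown here, since the only measured instance of this change is unreadable, the expectation for the step of a 1.1-fold lower number from compound 3 to compound 4 (0.06 log units; within the scatter) rests on little more than the number for compound 3, 25100 nM, and is taken as a small step in either direction. On that basis compound 4 is estimated at 22000 nM in this assay, with a range from 6000 nM to 90000 nM.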

Compound 4, half-maximal inhibitory concentration: 3670 nM
For compound 4 the middle estimate is 6.0-fold (0.78 log units) above the measured one, and the stated range ends above it.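

In this assay the change from methoxymethoxy to methoxy, with hydrogen in place of methoxy on a saturated chain carbon bound to an oxygen on an aromatic ring, gives a 6.8-fold lower number from compound 3 to compound 4 (0.84 log units; beyond the scatter) on the core of compound 3, and this step lies beyond the usual scatter. The same change on the core of compound 1 cannot be read, since compound 1 and compound 2 each return only a limit and no number, so the series holds a single readable instance: it shows what the change does on the core of compound 3 and does not show that the step carries over to the core of compound 1, in size or in direction. Nothing measured here speaks to what lies behind the step.

Still open, going by these compounds, is whether the step recurs on any further core, which would take a pair in which both members return numbers in this assay on a core other than that of compound 3. Also open, on these data alone, is how an amine, a carboxylic acid or a longer chain such as butoxy would compare with methoxy and methoxymethoxy at the same place on the core of compound 3.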